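This account rests on a few compounds, and the source may have more. Where it says the series, first, only, none or still open, it means among the compounds named here.

Working notes on the series. Compound 1 `Cc1ccc(-c2nn(-c3ccc(S(N)(=O)=O)cc3)cc2/C=C\C(=O)c2ccc(Cl)cc2)cc1` and compound 2 `COc1ccc(-c2nn(-c3ccc(S(N)(=O)=O)cc3)cc2/C=C\C(=O)c2ccc(Cl)cc2)cc1` share one core; compound 3 `Cc1ccc(-c2nn(-c3ccc(Cl)cc3)cc2-c2cc(-c3ccc(Cl)cc3)[nH]c2-c2ccc(F)cc2)cc1` and compound 4 `COc1ccc(-c2nn(-c3ccc(Cl)cc3)cc2-c2cc(-c3ccc(Cl)cc3)[nH]c2-c2ccc(F)cc2)cc1` share another, and the difference between the two cores is not broken down here. In a functional assay on the whole organism (strain Wistar albino) for inhibition, with Rattus norvegicus as the target, read by paw edema, with stated times of 1 h and 3 h, at a dose of 0.32 mmol/kg by the intraperitoneal route (a lower number here means less inhibition, a higher number more inhibition at the dose given (going by the name of the read-out)), compound 1 gives 47.6%, and in this assay compound 2 gives 56%. The change between them, (methoxy in place of methyl on an aromatic carbon), makes a step of a number 8.4 percentage points higher from compound 1 to compound 2 (within the scatter). In this assay compound 3 gives 21%, the lowest of the three numbers and beyond the scatter from compound 1 and from compound 2. Compound 4 carries the same change on its own core, (methoxy in place of methyl on an aromatic carbon); among the compounds shown this change occurs twice, once with both ends measured. The expectation for compound 4 in this assay rests on that single measured step, which lies within the scatter, so a step of similar size is expected here. The expected step is a number 6 percentage points higher from compound 3 to compound 4 (within the scatter). Compound 4 is estimated at 27%, with a range from 12% to 42%.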

Compound 4, a percentage reported as inhibition, in the whole organism at one dose (the size of the read-out at that dose, not a potency): 61.9%
Compound 4: the middle estimate sits 34.9 percentage points below what was measured; the whole stated range lies below it.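

In this assay, going from 4-methylphenyl to 4-methoxyphenyl on the core of compound 3 makes a step of a number 40.9 percentage points higher from compound 3 to compound 4 (beyond the scatter), and the same change does not give a step of the same size on both cores: the same change on two cores in this assay, a number 8.4 percentage points higher (within the scatter) from compound 1 to compound 2 and a number 40.9 percentage points higher (beyond the scatter) from compound 3 to compound 4, 32.5 percentage points apart, beyond the scatter of two such steps

The step measured on the core of compound 1 therefore cannot be carried over in size to the core of compound 3, and in this series the effect of this change depends on the core that carries it. Going by these compounds alone, with only two pairs, each read at a single dose, this does not show which part of the cores goes with the difference, nor does it give a potency for any compound.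

Going by these compounds, the two cores differ in more than one place, so which of those differences matters stays open. On these data alone, it also stays open whether a hydroxyl, an ethoxy or a dimethylamino group on the same aromatic carbon would give a large step on the core of compound 3 and a small one on the core of compound 1.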